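A few compounds are considered here, and "the series" means these few. Any claim that something is new, unique, unknown or untested is made for them only; others in the source may bear on it.

In an assay on isolated protein for inhibition of DNA topoisomerase 1 (Homo sapiens), with a stated time of 30 min, tested at 100 uM (on this read-out lower numbers stand for a weaker effect and higher numbers for a stronger effect at the one concentration tested), compound 1 `Oc1ccccc1-c1cc(-c2cccs2)cc(-c2ccccc2O)n1` gives 77.2%, whereas compound 2 `Oc1ccccc1-c1cc(-c2ccsc2)cc(-c2ccccc2O)n1` gives 0% and compound 3 `Oc1ccccc1-c1cc(-c2ccoc2)cc(-c2ccccc2O)n1` gives 1%. Compound 3 thus stands second highest of the three numbers, within the scatter of compound 2, and the step of a number 76.2 percentage points lower from compound 1 to compound 3 (beyond the scatter) separates it from the top. Compound 4 `Oc1ccccc1-c1cc(-c2cccnc2)cc(-c2ccccc2O)n1` differs from compound 3 in one place: pyridin-3-yl in place of furan-3-yl on an aromatic carbon. Among the measured compounds shown here, two measured steps bear on this change. The step of a number 1 percentage points higher from compound 2 to compound 3 (within the scatter) shows that exchanging one five-membered ring for another here left the read-out unchanged, while a number 77.2 percentage points lower from compound 1 to compound 2 (beyond the scatter) shows how much the ring at this place can matter. No six-membered ring has been measured, so the outcome is uncertain, and only a small step of a number 9 percentage points higher from compound 3 to compound 4 (within the scatter) is expected. Compound 4 is therefore estimated at 10%, between 0% and 45%.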

Compound 4, a percentage reported as inhibition, at one concentration (the size of the read-out at that concentration, not a potency): 66.4%
For compound 4 the middle estimate is 56.4 percentage points below the measured one; the whole stated range lies below it.
By their numbers in this assay, from the lowest: compounds 2 and 3 (each within the scatter of the next); then compound 4; then compound 1.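

High inhibition at this carbon is not confined to thiophen-2-yl: the six-membered pyridin-3-yl also gives a strong read-out, with a number 65.4 percentage points higher from compound 3 to compound 4 (beyond the scatter) and a number 66.4 percentage points higher from compound 2 to compound 4 (beyond the scatter) and only a number 10.8 percentage points lower from compound 1 to compound 4 (beyond the scatter). A single ring exchange here can therefore separate almost no inhibition from strong inhibition. Nothing available explains these differences.

Pyridin-3-yl differs from furan-3-yl in both ring size and hetero atom, and these compounds do not separate the two. Going by these compounds, whether phenyl, pyridin-2-yl or pyridin-4-yl would hold this level remains open.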